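The compounds below may be only part of what the source reports. "The series", "measured", "known", "first", "only" and "open" are said of these compounds alone.

Values in an ADME assay on HepG2 2.2.15 cells (Homo sapiens) for cytotoxicity, read by luminescence, with a stated time of 3 days; a lower number here means that less compound is tolerated, a higher number that more compound is tolerated:
compound 1 `O=C(Nc1ccc(F)c(Cl)c1)c1ccc(F)c(S(=O)(=O)N2CCCCC(O)CC2)c1`: 24000 nM
compound 2 `CC1(O)CCCN(S(=O)(=O)c2cc(C(=O)Nc3ccc(F)c(Cl)c3)ccc2F)CC1`: 11000 nM
compound 3 `CC(O)C1CCCCN(S(=O)(=O)c2cc(C(=O)Nc3ccc(F)c(Cl)c3)ccc2F)C1`: not yet measured

Of the two measured compounds, compound 2 has the lower number, 11000 nM. The next change is 3-(1-hydroxyethyl)azepan-1-yl in place of 4-hydroxy-4-methylazepan-1-yl on a sulfonyl sulfur, with 3-(1-hydroxyethyl)azepan-1-yl in place of 4-hydroxy-4-methylazepan-1-yl on a sulfonyl sulfur. For the measured compounds named here, only one measured step bears on it: a 2.2-fold lower number from compound 1 to compound 2 (0.34 log units; beyond the scatter). That modest step also replaced the group on the sulfonyl sulfur, but it went from an eight-membered to a seven-membered ring, whereas here the seven-membered ring stays. It therefore gives a rough scale and no direction for the present change. No step beyond the scatter is expected in this assay, and the expected move is a 1.3-fold higher number from compound 2 to compound 3 (0.10 log units; within the scatter). For compound 3 the estimated value is 14000 nM, with an expected range of 6500 nM to 30000 nM.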

Compound 3, half-maximal cytotoxic concentration: 2600 nM
Compound 3: the middle estimate sits 5.4-fold (0.73 log units) above what was measured; measured number below the stated range.
By their numbers in this assay, from the lowest: compound 3; then compound 2; then compound 1.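

Keeping the seven-membered ring and exchanging 4-hydroxy-4-methylazepan-1-yl for 3-(1-hydroxyethyl)azepan-1-yl on the sulfonyl sulfur gives a 4.2-fold lower number from compound 2 to compound 3 (0.63 log units; beyond the scatter) in this assay and so shows that this position remains sensitive with ring size held constant, which compound 1 and compound 2 could not show. Against the eight-membered ring group of compound 1, the change gives a 9.2-fold lower number from compound 1 to compound 3 (0.97 log units; beyond the scatter) and leaves compound 3 with the lowest number of the three. Nothing available accounts for the size or direction of these steps.

The compounds shown leave open whether the 1-hydroxyethyl chain itself or its place on the seven-membered ring drives the step. They also leave open whether an amine or a methoxy group in place of the hydroxyl on that chain would keep the lower number.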